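The compounds below may be only part of what the source reports. "The series", "measured", "known", "first", "only" and "open" are said of these compounds alone.

Working notes on the series. Compound 1 `Fc1ccc(OC(F)(F)F)cc1-c1ccc2c(c1)CC[C@H](CCc1nnn[nH]1)O2`, compound 2 `COc1cc(OC2CCC2)cc(-c2ccc3c(c2)CC[C@H](CCC(=O)O)O3)c1F` and compound 3 `Fc1ccc(OC2CCC2)cc1-c1ccc2c(c1)CC[C@H](CCc1nnn[nH]1)O2` have been run in a functional assay on HEK293 cells for agonist activity at Free fatty acid receptor 1 (Homo sapiens), read by HTRF and inositol phosphate accumulation, with a stated time of 60 min; a lower number here means that less compound is needed, a higher number that more compound is needed for the effect; compound 4 `COc1cc(OC(F)(F)F)cc(-c2ccc3c(c2)CC[C@H](CCC(=O)O)O3)c1F` has not yet been measured there. In this assay compound 1 gives > 10000 nM, which is a limit of the assay and not a number. In this assay compound 2 gives > 10000 nM, again a limit of the assay. In this assay compound 3 gives > 10000 nM, also a limit of the assay. What the three measured compounds have in common is the limit of > 10000 nM in this assay, at which 3 of the 3 values shown sit.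

Within the data shown here, the one change that occurs twice in the set is trifluoromethyl in place of cyclobutyl on an oxygen on an aromatic ring, and the step it made in this assay runs a step that the two limits leave unreadable from compound 3 to compound 1. Made on the core of compound 2 the same change reads (trifluoromethyl in place of cyclobutyl on an oxygen on an aromatic ring); the two place lines agree word for word, so this is the same change at the same kind of site. The difference between the core of compound 2 and the core of compound 3 is not broken down here.

From compound 2 to compound 4 the step in this assay is expected to run a step that the limit leaves unreadable from compound 2 to compound 4, which rests on the limit of > 10000 nM in this assay, at which 3 of the 3 values shown sit, and on the unreadable step that the two limits leave unreadable from compound 3 to compound 1 that the same change made. Compound 4 is therefore expected at 12000 nM in this assay, with an estimated range from 3000 nM to 40000 nM, and most probably as a limit again rather than a number.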

Compound 4, half-maximal effective concentration: 4400 nM
For compound 4 the middle estimate is 2.7-fold (0.44 log units) above the measured one; the measured number falls inside the stated range.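

On the core of compound 2, trifluoromethyl in place of cyclobutyl on an oxygen on an aromatic ring gives, in this assay, an at least 2.2-fold lower number from compound 2 to compound 4 (0.35 log units; beyond the scatter), so on this core the change from cyclobutyloxy to trifluoromethoxy ends in a readable value. The same change on the core of compound 3 cannot be read, since both of its ends are limits, and the series therefore shows neither that the step carries from one core to the other nor that it fails to carry. Compound 2 gives > 10000 nM, a limit of the assay and not a number, so the step has a lower bound but no known size, and the comparison between cores rests on very few numbers: the limit of > 10000 nM in this assay, at which 3 of the 4 values shown sit.

On these data alone, the difference between the core of compound 2 and the core of compound 3 is not broken down, so it remains open which part of it, if any, decides whether this change leads to a readable value. Also open, as far as these compounds go, is how a difluoromethyl group or a longer alkyl chain on the same oxygen would compare with trifluoromethyl on the core of compound 2.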